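Swapping the dimethyl pattern on the aryl piperazine

The compounds below may be only part of what the source reports. "The series", "measured", "known", "first", "only" and "open" are said of these compounds alone.

In a functional assay on HL-60 cells (Homo sapiens) for inhibition, read by MTT assay, with a stated time of 72 h (on this read-out higher numbers stand for weaker inhibition and lower numbers for stronger inhibition), compound 3 `Cc1nc(-c2ccccc2)c(C(=O)N2CCN(c3cccc(C)c3C)CC2)o1` gives 35 nM and has the lowest number shown. Compound 2 `Cc1nc(-c2ccccc2)c(C(=O)N2CCN(c3cccc(C(F)(F)F)c3)CC2)o1` gives 153 nM in this assay. Compound 1 `Cc1ccc(N2CCN(C(=O)c3oc(C)nc3-c3ccccc3)CC2)cc1` reports only a limit in this assay, > 1000 nM. Two steps are therefore known: a 4.4-fold lower number from compound 2 to compound 3 (0.64 log units; beyond the scatter) and an at least 28-fold lower number from compound 1 to compound 3 (1.45 log units; beyond the scatter). The change now considered is 3,5-dimethylphenyl in place of 2,3-dimethylphenyl on an amine nitrogen in a ring, giving compound 4 `Cc1cc(C)cc(N2CCN(C(=O)c3oc(C)nc3-c3ccccc3)CC2)c1`. Both measured steps bear on it: every aryl group that was not 2,3-dimethylphenyl gave a higher number, and the limit for compound 1 the limit of > 1000 nM in this assay, at which 1 of the 3 values shown sits, is the weakest. Moving methyl groups within the ring is therefore expected to cost something, so a modest rise, a 3.1-fold higher number from compound 3 to compound 4 (0.50 log units; beyond the scatter), is estimated. Compound 4 is expected to give about 110 nM, between 35 nM and 450 nM, in this assay.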

Compound 4, half-maximal inhibitory concentration: 34.5 nM
The estimate for compound 4 lay 3.2-fold (0.50 log units) above the measured number, outside the stated range (below it).
By their numbers in this assay, from the lowest: compounds 4 and 3 (each within the scatter of the next); then compound 2. At a limit, above all of these: compound 1.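

In this assay, among the compounds shown here, 3,5-dimethylphenyl and 2,3-dimethylphenyl on the ring nitrogen lie within the scatter of each other, with a 1.0-fold lower number from compound 3 to compound 4 (0.01 log units; within the scatter) as the step, so this place accepts two different dimethyl patterns, which the earlier compounds could not show. The advantage over 3-(trifluoromethyl)phenyl also holds for the new pattern, with a 4.4-fold lower number from compound 2 to compound 4 (0.65 log units; beyond the scatter) as the step. The step of an at least 28-fold lower number from compound 1 to compound 4 (1.46 log units; beyond the scatter) starts from a limit, the only one shown: the limit of > 1000 nM in this assay, at which 1 of the 4 values shown sits.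

From the compounds shown here alone, whether a methoxy group or a chlorine on the phenyl ring would match the two dimethylphenyl compounds stays open. Why 4-methylphenyl in compound 1 stands apart from them also stays open.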